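N-methylation step from compound 1 to compound 4

The compounds below may be only part of what the source reports. "The series", "measured", "known", "first", "only" and "open" are said of these compounds alone.

Measured in a functional assay on PC-3 cells (Homo sapiens) for cytotoxicity, read by MTT assay, with a stated time of 48 h; on this read-out lower numbers stand for higher toxicity in this test and higher numbers for lower toxicity in this test:
compound 1 `O=Cc1c(Nc2ccccc2)oc2ccc(Cl)cc2c1=O`: 8300 nM
compound 2 `O=Cc1c(Nc2ccccc2)oc2ccc(F)cc2c1=O`: 8600 nM
compound 3 `O=Cc1c(Nc2ccccc2)oc2cc(Cl)ccc2c1=O`: 2500 nM

Compound 1 stands second highest of the three numbers. Its nearest neighbour is compound 2, and the step of a 1.0-fold higher number from compound 1 to compound 2 (0.02 log units; within the scatter) lies within the scatter. For the measured compounds named here, compound 3 is the furthest away, and the gap between compound 1 and compound 3 is beyond the scatter; no single-point step between these two is given.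

Compound 4 `CN(c1ccccc1)c1oc2ccc(Cl)cc2c(=O)c1C=O` differs from compound 1 by methyl in place of hydrogen on a nitrogen on an aromatic ring. Going by the values given here, no measured step touches this nitrogen; the only single-point step, a 1.0-fold higher number from compound 1 to compound 2 (0.02 log units; within the scatter), concerns the halogen on the shared core and is within the scatter, so it gives no basis for a direction. No step beyond the scatter is therefore expected, estimated as no change at the digits printed from compound 1 to compound 4 (within the scatter). For compound 4 the estimate is 8300 nM, range 2800 nM to 25000 nM.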

Compound 4, concentration lethal to 50% of the cells: 2100 nM
The estimate for compound 4 lay 4.0-fold (0.60 log units) above the measured number, and the stated range ends above it.
By their numbers in this assay, from the lowest: compounds 4 and 3 (each within the scatter of the next); then compounds 1 and 2 (each within the scatter of the next).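

In this assay methyl in place of hydrogen on the nitrogen gives a 4.0-fold lower number from compound 1 to compound 4 (0.60 log units; beyond the scatter) and lies beyond the scatter, whereas fluoro in place of chloro gives a 1.0-fold higher number from compound 1 to compound 2 (0.02 log units; within the scatter) and stays within it. Of the two single changes shown on compound 1, only the one at this nitrogen moves the number past the scatter. No measured evidence bears on the reason for this step.

From the compounds shown here alone, whether an ethyl group or a longer chain on this nitrogen would move the number further remains open. Also open, going by these compounds, is whether methyl gives a similar step on compound 2 or compound 3.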